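The source may hold more compounds than are shown below. What is called first, only, known or untested is meant among the compounds shown, and "the series" means these compounds.

In an ADME assay on CEM-SS cells (Homo sapiens) for cytotoxicity, read by XTT assay, with a stated time of 6 days (on this read-out higher numbers stand for lower toxicity in this test and lower numbers for higher toxicity in this test), compound 1 `CCCC(=O)OCSc1ccccc1C(=O)NCCC(N)=O` gives > 100 uM, which is a limit of the assay and not a number. Among the measured compounds shown here, compound 2 `CCCC(=O)OCSc1ccccc1C(=O)NCCCNC(C)=O` gives 21.1 uM, the only actual number so far, so it has no numeric rank. On the ceiling of the assay, the record to keep in view is the limit of > 100 uM in this assay, at which 1 of the 2 values shown sits.

Compound 3 `CCCC(=O)OCSc1ccccc1C(=O)N(C)CC(N)=O` differs from compound 2 by (carbamoylmethyl)(methyl)amino in place of (3-acetamidopropyl)amino on a carbonyl carbon.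

For the measured compounds named here, only one measured step bears on this change: an at least 4.7-fold lower number from compound 1 to compound 2 (0.67 log units; beyond the scatter). That step replaced carbamoyl with acetamidomethyl, whereas the entering group in compound 3 carries carbamoyl again. Going by the values given here, the evidence is thin, since the amide nitrogen also gains a methyl group and the chain differs, and no measured step covers either change. A move towards a higher number in this assay is therefore expected, of a size comparable to that single step, and a result reported only as a limit would not surprise.

The expected change is a 3.3-fold higher number from compound 2 to compound 3 (0.52 log units; beyond the scatter).

For compound 3 the estimated value is 70 uM, with an expected range of 25 uM to 200 uM.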

Compound 3, half-maximal toxic concentration: 55.3 uM
Beside the measured number, compound 3's estimate is 1.3-fold (0.10 log units) above it, within the range that was stated.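

In this assay, (carbamoylmethyl)(methyl)amino in place of (3-acetamidopropyl)amino on a carbonyl carbon gives a 2.6-fold higher number from compound 2 to compound 3 (0.42 log units; beyond the scatter), so this position has now moved the read-out in a second, structurally different pair. Among the compounds shown, the two with a terminal carbamoyl, compound 1 and compound 3, both stand higher than compound 2, with no compound going against this. Between those two, the data give an at least 1.8-fold lower number from compound 1 to compound 3 (0.25 log units; that floor lies within the scatter), and the floor of that step lies within the scatter, so the two are not separated. Compound 1 remains a limit and not a number: the limit of > 100 uM in this assay, at which 1 of the 3 values shown sits.

The change from (2-carbamoylethyl)amino to (carbamoylmethyl)(methyl)amino alters the chain and adds the methyl on the nitrogen at once, and the data do not divide the two contributions. As far as these compounds go, how a carboxylic acid or a primary amine at the chain end, or a longer chain bearing carbamoyl, would fall in this read-out remains open.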